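A few compounds are considered here, and "the series" means these few. Any claim that something is new, unique, unknown or untested is made for them only; others in the source may bear on it.

Compound 1 `Cc1cc(C(=O)O)ccc1CN1CCC[C@H](O[C@H](CO)c2ccccc2)[C@@H]1c1ccccc1` is the starting point in an assay on isolated protein for activation of cGMP-dependent protein kinase 1 (Homo sapiens), read by ADP-Glo, with stated times of 30 min and 2 h; a higher number here means that more compound is needed for the effect, a lower number that less compound is needed. In this assay compound 1 reaches only the limit of the assay, giving > 200000 nM, which is a limit and not a number. That places compound 1 at the limit of > 200000 nM in this assay, at which 1 of the 2 values shown sits. Compound 2 `Cc1nc(C(=O)O)ccc1CN1CCC[C@H](O[C@H](CO)c2cc(Cl)cc(Cl)c2)[C@@H]1c1ccccc1` differs from compound 1 in more than one place. In this assay compound 2 gives a value of 144000 nM, and the two values show no more than that compound 2 yields a number where compound 1 does not. Compound 3 `Cc1cc(C(=O)O)ccc1CN1CCC[C@H](O[C@H](CO)c2cccc(Cl)c2)[C@@H]1c1ccccc1` is the compound still to be measured in this assay. It differs from compound 1 by chloro in place of hydrogen on an aromatic carbon. Within the data shown here, no measured step accompanies this change, so its size in this assay is open; a step within the scatter, or at most a small one toward less compound being needed, is expected. Compound 3 is therefore expected to give about 180000 nM in this assay, between 60000 nM and 600000 nM. The expected step is thus an at least 1.1-fold lower number from compound 1 to compound 3 (0.04 log units; that floor lies within the scatter).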

Compound 3, half-maximal effective concentration: 93000 nM
Compound 3: the middle estimate sits 1.9-fold (0.29 log units) above what was measured, and the stated range covers the measured number.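

Going from phenyl to 3-chlorophenyl within the 2-hydroxy-1-phenylethyl group gives an at least 2.1-fold lower number from compound 1 to compound 3 (0.33 log units; beyond the scatter) in this assay. Among these compounds, this is the first change on this aromatic ring that can be read on its own, since compound 2 differs from compound 1 in more than one place, and it shows that a single chloro on this ring is enough to turn a limit into a number. The size of the step remains a floor and not a full measure, because compound 1 stands at a limit of the assay: the limit of > 200000 nM in this assay, at which 1 of the 3 values shown sits.

The compounds shown leave open whether a fluoro, a methyl or a methoxy group at this place would act as chloro does. They also do not separate the part played by each of the several differences in compound 2.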